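Tetrahydroisoquinoline amide in the nitro sulfone series

This account rests on a few compounds, and the source may have more. Where it says the series, first, only, none or still open, it means among the compounds named here.

Measured so far in an ADME assay on HepG2 cells (Homo sapiens) for cytotoxicity, read by CellTiter-Glo and ATP content, with a stated time of 72 h; on this read-out higher numbers stand for an effect only at larger amounts of compound and lower numbers for an effect already at smaller amounts:
Compound 1 `CS(=O)(=O)c1ccc(C(=O)NCCC(=O)N2CCCCC2)cc1[N+](=O)[O-]` gives a value that is a limit of the assay, > 27000 nM.
Compound 2 `CN(Cc1ccccc1F)C(=O)C1CCN(C(=O)c2ccc(S(C)(=O)=O)c([N+](=O)[O-])c2)CC1` also gives only a limit, > 27000 nM.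
Compound 3 `CS(=O)(=O)c1ccc(C(=O)NCCCC(=O)N2Cc3ccccc3C2)cc1[N+](=O)[O-]` likewise gives a limit, > 27000 nM.

The whole picture so far is the limit of > 27000 nM in this assay, at which 3 of the 3 values shown sit. Going by the values given here, compound 1 therefore stands level with the other two, with no number of its own, and no step between measured compounds can be drawn, as none of them differs from another in a single place. Compound 4 `CS(=O)(=O)c1ccc(C(=O)NCCC(=O)N2CCc3ccccc3C2)cc1[N+](=O)[O-]` differs from compound 1 by 1,2,3,4-tetrahydroisoquinolin-2-yl in place of piperidin-1-yl on a carbonyl carbon. With every measured value a limit, the series gives no direction to read from. The expected step is a step that the limit leaves unreadable from compound 1 to compound 4, which is none beyond the scatter. Compound 4 is expected to give 30000 nM in this assay, in a range from 14000 nM to 65000 nM, and most likely to be reported again as a limit rather than a number.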

Compound 4, half-maximal effective concentration: > 27000 nM
Compound 4: no number, only a limit; the forecaster's own chance of this, stated with the estimate: 80%; the middle value is on the limit's open side.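

Compound 1 and compound 4 both give only a limit in this assay, so no step between them can be read: the limit of > 27000 nM in this assay, at which 4 of the 4 values shown sit.

The compounds shown leave open whether 1,2,3,4-tetrahydroisoquinolin-2-yl in place of piperidin-1-yl on a carbonyl carbon changes this read-out at all, and at what amount any of them would show an effect.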